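A few compounds are considered here, and "the series" means these few. Any claim that something is new, unique, unknown or untested is made for them only; others in the source may bear on it.

Three compounds have been measured in a functional assay on HCT-116 cells (Homo sapiens) for antiproliferative activity, read by CCK-8 assay, with a stated time of 72 h, tested at 2 uM; on this read-out higher numbers stand for a stronger effect at the one concentration tested and lower numbers for a weaker effect:

compound 1 `CCCCn1cnc2c(NCc3ccc(C(=O)Nc4ccccc4N)cc3)nc(Cl)nc21` gives 4.89%
compound 2 `Nc1ccccc1NC(=O)c1ccc(CNc2nc(Cl)nc3c2ncn3C2CCCC2)cc1` gives 75.6%
compound 3 `CCCCn1cnc2c(Nc3cccc(Cl)c3)nc(NCOCc3ccc(C(=O)Nc4ccccc4N)cc3)nc21` gives 58.9%

Compound 1 and compound 2 share one core and differ in a single place: cyclopentyl in place of butyl on an aromatic nitrogen. This one exchange carries a step of a number 70.7 percentage points higher from compound 1 to compound 2 (beyond the scatter), so in this assay the cyclopentyl compound reaches a far stronger effect than the butyl compound at the same concentration.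

Compound 3 has a different, larger core; how it differs from the core of compound 1 is not broken down here. Compound 3 stands second of the three measured numbers, beyond the scatter from both compound 2 and compound 1.

Compound 4 `Nc1ccccc1NC(=O)c1ccc(COCNc2nc(Nc3cccc(Cl)c3)c3ncn(C4CCCC4)c3n2)cc1` is not yet measured. It differs from compound 3 in one place: cyclopentyl in place of butyl on an aromatic nitrogen. The place is the same, word for word, as in the step from compound 1 to compound 2, so this is the same change on a different core. Since compound 3 already gives a fairly high number, the room left before a full effect is smaller than it was for compound 1, and the step is expected to be smaller than the earlier one: an estimated a number 25.1 percentage points higher from compound 3 to compound 4 (beyond the scatter). On that basis compound 4 is expected to give about 84% in this assay, with a likely range from 65% to 97%.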

Compound 4, a percentage reported as inhibition, at one concentration (the size of the read-out at that concentration, not a potency): 29.2%
Compound 4: the middle estimate sits 54.8 percentage points above what was measured; measured number outside the range, below it.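

The exchange of butyl for cyclopentyl on an aromatic nitrogen does not carry over from one core to the other: in this assay, it gives a number 29.7 percentage points lower from compound 3 to compound 4 (beyond the scatter), so the cyclopentyl compound is the weaker one on this larger core. Set beside the earlier step, the same change raises the number on one core and lowers it on the other, and the gap between the two steps is real rather than noise: the same change on two cores in this assay, a number 70.7 percentage points higher (beyond the scatter) from compound 1 to compound 2 and a number 29.7 percentage points lower (beyond the scatter) from compound 3 to compound 4, 100.4 percentage points apart, beyond the scatter of two such steps. This shows that, among these four compounds, the effect of the exchange depends on the core that carries it, but it does not show which feature of the larger core turns the step around, and two pairs tested at a single concentration cannot establish a rule for the wider series.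

On these data alone, it remains open how other groups on that same aromatic nitrogen, such as methyl, a longer chain like hexyl, or a chain ending in an amine, would behave on each of the two cores. Also open is which of the differences between the two cores decides the direction of the step, as no pair shown changes those differences one at a time.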